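Chloro to hydrogen: expected lipophilicity of compound 3

A few compounds are considered here, and "the series" means these few. Any claim that something is new, unique, unknown or untested is made for them only; others in the source may bear on it.

Measured so far:
compound 1 `O=C1/C(=C/c2ccc(F)cc2)CCC/C1=C\c1ccc([N+](=O)[O-])cc1` — 5.08
compound 2 `O=C1/C(=C/c2ccc(Cl)cc2)CCC/C1=C\c1ccc([N+](=O)[O-])cc1` — 5.08

Within the data shown here, in a physicochemical assay for lipophilicity (on this read-out higher numbers stand for higher lipophilicity and lower numbers for lower lipophilicity), compound 2 stands level with compound 1; the single measured step, no change at the digits printed from compound 1 to compound 2 (within the scatter), exchanges one halogen for another and lies within the scatter. Compound 3 `O=C1/C(=C/c2ccccc2)CCC/C1=C\c1ccc([N+](=O)[O-])cc1` differs from compound 2 by hydrogen in place of chloro on an aromatic carbon. Among the measured compounds shown here, no measured step removes a halogen outright, so the comparison of compound 1 with compound 2 does not settle the size; the loss of a chlorine is expected to lower the read-out beyond the scatter. The expected step is a number 0.68 log units lower from compound 2 to compound 3 (beyond the scatter). Compound 3 is estimated at 4.4, within 4 to 4.8.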

Compound 3, partition coefficient: 5.08
Compound 3: the middle estimate sits 0.68 log units below what was measured; measured number above the stated range.
By their numbers in this assay, from the lowest: compounds 1, 2 and 3 (each within the scatter of the next).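

In this assay, removing the halogen outright gives no change at the digits printed from compound 2 to compound 3 (within the scatter), and replacing the lighter halogen gives no change at the digits printed from compound 1 to compound 3 (within the scatter). Hydrogen, fluoro and chloro on this aromatic carbon, para to a large group, are therefore not told apart in this assay, so the earlier halogen exchange now extends to the halogen-free compound. No measurement at hand explains this flat result.

Going by these compounds, whether an amine, a carboxylic acid or a longer chain on this carbon would separate from these three remains open. Also open, on these data alone, is whether the same changes read alike elsewhere on the core of compound 1.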